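The source may hold more compounds than are shown below. What is called first, only, known or untested is meant among the compounds shown, and "the series" means these compounds.

Compound 1, `CCN(CC)c1cc2[nH]c(C3CCCCC3)nc2cc1NC(=O)NCc1ccccc1`, belongs to a small set of compounds sharing one core. In an ADME assay on Vero cells (Chlorocebus sabaeus) for cytotoxicity, read by resazurin assay, with a stated time of 3 days (on this read-out higher numbers stand for weaker inhibition and lower numbers for stronger inhibition), compound 1 gives > 100 ug/mL, which is a limit of the assay and not a number. Compound 2, `O=C(NCc1ccccc1)Nc1cc2nc(C3CCCCC3)[nH]c2cc1N1CCCC1`, in this assay gives > 100 ug/mL, likewise a limit. Compound 3, `CCOCCOC(=O)Nc1cc2nc(C3CCCCC3)[nH]c2cc1N(C)C`, in this assay gives > 100 ug/mL, also a limit. Among the measured compounds shown here, the only step between compounds differing in one place, a step that the two limits leave unreadable from compound 1 to compound 2, is therefore of unreadable size, and the limit of > 100 ug/mL in this assay, at which 3 of the 3 values shown sit, is the whole of the evidence on where this series stands.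

Compound 4, `CCN(CC)c1cc2[nH]c(C3CCCCC3)nc2cc1NC(=O)c1cccc(Br)c1`, differs from compound 1 in one place: 3-bromophenyl in place of benzylamino on a carbonyl carbon. For the measured compounds named here, no measured step touches the benzylcarbamoyl to (3-bromophenyl)carbonyl change, so nothing on the numbers speaks for or against a shift. Because the limit of > 100 ug/mL in this assay, at which 3 of the 3 values shown sit, holds every value shown at the limit, compound 4 is expected to sit near that limit as well. The step of a number no higher from compound 1 to compound 4 (the limit leaves the size open) is expected to be none beyond the scatter. Compound 4 is estimated at 100 ug/mL, with a range from 30 ug/mL to 200 ug/mL.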

Compound 4, half-maximal inhibitory concentration: > 100 ug/mL
Compound 4: only a limit was reported (the forecaster's own chance of this, stated with the estimate: 70%); the middle value lies on the limit itself.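

Compound 1 and compound 4 both stand at a limit in this assay, and the step between them cannot be read. The compounds shown leave open where the actual values lie and whether any change on the shared core moves them: the limit of > 100 ug/mL in this assay, at which 4 of the 4 values shown sit.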